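This account rests on a few compounds, and the source may have more. Where it says the series, first, only, none or still open, it means among the compounds named here.

Measured in an ADME assay on MDCK cells (Canis lupus familiaris) for cytotoxicity, read by MTT assay, with a stated time of 48 h; a lower number here means that less compound is tolerated, a higher number that more compound is tolerated:
Compound 1 `COc1ccc(-c2cn(CC3=C(Cl)c4ccc(-c5cccs5)nc4CC3)nn2)cc1`: > 300 ug/mL (a limit, not a number)
Compound 2 `FC(F)(F)Oc1ccc(-c2cn(CC3=C(Cl)c4ccc(-c5cccs5)nc4CC3)nn2)cc1`: > 300 ug/mL (a limit, not a number)
Compound 3 `O=[N+]([O-])c1ccc(-c2cn(CC3=C(Cl)c4ccc(-c5cccs5)nc4CC3)nn2)cc1`: 40 ug/mL

Going by the values given here, compound 3 carries the only actual number and lies on the less tolerated side of the other two compounds. The remaining values are the limit of > 300 ug/mL in this assay, at which 2 of the 3 values shown sit.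

The next compound is compound 4 `FC(F)(F)c1ccccc1-c1cn(CC2=C(Cl)c3ccc(-c4cccs4)nc3CC2)nn1`. The change is 2-(trifluoromethyl)phenyl in place of 4-nitrophenyl on an aromatic carbon of a five-membered aromatic ring with 3 nitrogen.

Among the compounds with values here, two measured steps bear on this change, and both bring in the nitro group that compound 4 lacks. The first is an at least 7.5-fold lower number from compound 1 to compound 3 (0.87 log units; beyond the scatter) and the second is an at least 7.5-fold lower number from compound 2 to compound 3 (0.87 log units; beyond the scatter). Both lie beyond the scatter, and each gives only a minimum size. The step that the two limits leave unreadable from compound 1 to compound 2 adds nothing on size. Within the data shown here, no measured compound carries the 2-(trifluoromethyl)phenyl group, so the read-across is indirect.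

Losing the nitro group is therefore expected to reverse much of the drop in this assay, giving a higher number. The expected change is a 5.0-fold higher number from compound 3 to compound 4 (0.70 log units; beyond the scatter). For compound 4 the estimated value is 200 ug/mL, with an expected range of 70 ug/mL to 450 ug/mL.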

Compound 4, half-maximal cytotoxic concentration: > 300 ug/mL
Compound 4 ended at the assay's limit (the forecaster's own chance of this, stated with the estimate: 50%); at least 1.5-fold (0.17 log units) between middle value and limit.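

In this assay, 2-(trifluoromethyl)phenyl in place of 4-nitrophenyl on the aromatic carbon of the five-membered aromatic ring gives an at least 7.5-fold higher number from compound 3 to compound 4 (0.87 log units; beyond the scatter), so the low number of compound 3 does not extend to this group at this position. Going by these compounds alone, the series now holds a phenyl group with trifluoromethyl directly on the ring alongside the 4-methoxyphenyl of compound 1 and the 4-(trifluoromethoxy)phenyl of compound 2, and compound 3 is the one compound that goes against the run of limit values: the limit of > 300 ug/mL in this assay, at which 3 of the 4 values shown sit. The steps from compound 1 and from compound 2 to compound 4 cannot be read, so these three compounds cannot be placed in any order.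

Within the data shown here, with 4-nitrophenyl as the only group giving an actual number, the data cannot tell whether the nitro group alone accounts for the lower value in this assay. From the compounds shown here alone, how a phenyl ring carrying an amine, a nitrile or a carboxylic acid would read at this position remains open, and such compounds could show whether other groups also give a number rather than a limit.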